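This account rests on a few compounds, and the source may have more. Where it says the series, first, only, none or still open, it means among the compounds named here.

The series shares one core, seen in compound 1 `Cc1ccc2c(c1)/C(=N/NC(=S)N/N=C/c1ccccn1)C(=O)N2`, compound 2 `Cc1ccc2c(c1)/C(=N/NC(=S)N/N=C/c1c(F)cccc1Cl)C(=O)N2` and compound 3 `Cc1ccc(O)c(/C=N/NC(=S)N/N=C2\C(=O)Nc3ccc(C)cc32)c1`, and varies only in the aryl group on a carbon with a double bond to nitrogen. In a functional assay on HeLa cells (Homo sapiens) for inhibition, read by MTT assay (on this read-out higher numbers stand for weaker inhibition and lower numbers for stronger inhibition), compound 1 gives 3150 nM. In this assay compound 2 gives 1510 nM, a 2.1-fold lower number from compound 1 to compound 2 (0.32 log units; beyond the scatter). Compound 3 reports only a limit in this assay, > 50000 nM, and so sits at the limit of > 50000 nM in this assay, at which 1 of the 3 values shown sits; its true number is not known. Against the two measured compounds this is an at least 15-fold higher number from compound 1 to compound 3 (1.20 log units; beyond the scatter) and an at least 33-fold higher number from compound 2 to compound 3 (1.51 log units; beyond the scatter).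

Compound 4 `Cc1ccc2c(c1)/C(=N/NC(=S)N/N=C/c1ccc(Br)cc1)C(=O)N2` is the next step from compound 3: 4-bromophenyl in place of 2-hydroxy-5-methylphenyl on a carbon with a double bond to nitrogen. The entering 4-bromophenyl brings no hydrogen-bond donor or acceptor and thus stands closer to compound 2 than to compound 3. The two large steps bear on this change in reverse, since the 2-hydroxy-5-methylphenyl group they introduced now leaves. A return toward the range of compound 1 and compound 2 is therefore expected, and the step of an at least 20-fold lower number from compound 3 to compound 4 (1.30 log units; beyond the scatter) is an estimate only. For compound 4 in this assay the expected value is 2500 nM, with a range from 800 nM to 12000 nM.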

Compound 4, half-maximal inhibitory concentration: > 50000 nM
Compound 4 gave a limit, no number; the forecaster's own chance of this, stated with the estimate: 15%; middle value at least 20-fold (1.30 log units) away from the limit.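

In this assay the 4-bromophenyl group does not join the two measured compounds, with an at least 33-fold higher number from compound 2 to compound 4 (1.51 log units; beyond the scatter) and an at least 15-fold higher number from compound 1 to compound 4 (1.20 log units; beyond the scatter). The hydrogen-bond donor and acceptor counted on 2-hydroxy-5-methylphenyl therefore cannot be what separates compound 3 from compound 1 and compound 2, since 4-bromophenyl counts none and falls on the same side as compound 3. The step between compound 3 and compound 4 cannot be read, as both are limits, and this position now divides the series into measured values and limits: the limit of > 50000 nM in this assay, at which 2 of the 4 values shown sit.

On these data alone, whether an unsubstituted phenyl, a 4-chlorophenyl or a 4-aminophenyl group would return a measurable number at this position remains open. As far as these compounds go, the true values of compound 3 and compound 4 also remain unknown, so no order between them can be given.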